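Swapping chloro for fluoro on a mitochondrial activator

This account rests on a few compounds, and the source may have more. Where it says the series, first, only, none or still open, it means among the compounds named here.

Two compounds from this study share one core and differ only on the attached benzene ring. Compound 1 `Oc1nc2nonc2nc1Nc1ccc(OC(F)(F)F)cc1Cl` gives 1400 nM in an assay on mitochondria from L6 cells (Rattus norvegicus) for activation, with a stated time of 90 min (a higher number here means that more compound is needed for the effect, a lower number that less compound is needed), the lowest of the two numbers seen. Among the compounds with values here, compound 2 `Oc1nc2nonc2nc1Nc1ccccc1Cl` gives 6300 nM in this assay, and the single measured step, a 4.5-fold higher number from compound 1 to compound 2 (0.65 log units; beyond the scatter), comes from a hydrogen in place of trifluoromethoxy on an aromatic carbon. Compound 3 `Oc1nc2nonc2nc1Nc1ccc(OC(F)(F)F)cc1F` is not yet measured. Its change from compound 1 is fluoro in place of chloro on an aromatic carbon. Within the data shown here, no measured step here involves a change of the chloro group, so the step from compound 1 to compound 2 does not bear directly on it; it only shows that a change on this ring can move the number modestly. The estimated step is therefore small: a 1.6-fold higher number from compound 1 to compound 3 (0.20 log units; within the scatter), within or near the scatter. Compound 3 is expected to give about 2200 nM, between 800 nM and 6000 nM.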

Compound 3, half-maximal effective concentration: 2300 nM
The estimate for compound 3 lay 1.0-fold (0.02 log units) below the measured number; the measured number falls inside the stated range.
By their numbers in this assay, from the lowest: compounds 1 and 3 (each within the scatter of the next); then compound 2.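

Within the data shown here, this is the first measured change at the position that carries chloro, an aromatic carbon ortho to a large group, and in this assay fluoro in place of chloro gives a 1.6-fold higher number from compound 1 to compound 3 (0.22 log units; within the scatter) on the ring that keeps its trifluoromethoxy group. This swap therefore stays within what repeated measurements would give, whereas removing the trifluoromethoxy group gives a 4.5-fold higher number from compound 1 to compound 2 (0.65 log units; beyond the scatter) and moves the number beyond that scatter. Nothing available explains why the chloro and fluoro compounds read alike.

The compounds shown leave open whether a different group at this position, such as a methyl group, a methoxy group or an amine, would keep the number in the same range. They also leave open whether fluoro and chloro would still match on a ring without the trifluoromethoxy group.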